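The compounds below may be only part of what the source reports. "The series", "measured", "known", "first", "only" and "open" are said of these compounds alone.

Two compounds of this series carry measured numbers in an assay on L1210 cells for inhibition of Dihydrofolate reductase (Mus musculus); a higher number here means a weaker inhibitor, a lower number a stronger inhibitor. Compound 1 `CN(Cc1cnc2nc(N)nc(N)c2n1)c1ccc(C(=O)NC(CCC(=O)NN)C(=O)O)cc1` gives 0.012 uM, and compound 2 `CN(Cc1cnc2nc(N)nc(N)c2n1)c1ccc(C(=O)NC(CCC(=O)O)C(=O)OC(C)(C)C)cc1` gives 0.035 uM. Of the two, compound 2 stands at the higher number, and the gap to compound 1 lies beyond the usual scatter of repeated measurements, so compound 1 is the stronger inhibitor of the pair on the numbers shown. The step to compound 3 `COC(=O)CCC(NC(=O)c1ccc(N(C)Cc2cnc3nc(N)nc(N)c3n2)cc1)C(=O)OC(C)(C)C` keeps the shared core and the rest of compound 2 unchanged and alters only one place: methyl in place of hydrogen on an oxygen next to a carbonyl group. Written one bond further out, the carboxy group of compound 2 becomes a methoxycarbonyl group in compound 3. Within the data shown here, no measured pair in this set shows this exact change, so its size has to be judged from the two numbers at hand. Capping the acid is expected to cost some potency, and the step of a 1.7-fold higher number from compound 2 to compound 3 (0.23 log units; within the scatter) is estimated to be small and toward a higher number, at the edge of the scatter. Compound 3 is therefore expected to give about 0.06 uM, within a range of 0.02 uM to 0.2 uM.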

Compound 3, concentration for 50% inhibition: 0.019 uM
For compound 3 the middle estimate is 3.2-fold (0.50 log units) above the measured one; the measured number lies below the stated range.
By their numbers in this assay, from the lowest: compounds 1, 3 and 2 (each within the scatter of the next, the first and the last beyond it).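

Turning the carboxy group of compound 2 into the methoxycarbonyl group of compound 3, with methyl in place of hydrogen on an oxygen next to a carbonyl group, gives a 1.8-fold lower number from compound 2 to compound 3 (0.27 log units; within the scatter) in this assay. At this place, then, the free carboxylic acid is not required to keep inhibition at the level seen for compound 2, and capping it as the methyl ester leaves the two compounds level within the scatter. Nothing available here explains why the change is tolerated.

What the compounds shown leave open is how far this tolerance extends, since a single step at one place cannot show whether a longer chain such as ethyl on the same oxygen, or a primary amide in place of the ester, would stay level as well. Among these compounds, they also leave open whether the same methyl capping would behave alike on the other carboxy group of the series, as the only pair that can be read directly is this one, in this one assay.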